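Methoxy in place of acetamido: notes toward compound 3

The source may hold more compounds than are shown below. What is called first, only, known or untested is meant among the compounds shown, and "the series" means these compounds.

compound 1 `COc1cc(OC)cc(C(=CC#N)c2ccc(OC)c(NC(C)=O)c2)c1` gives 92 nM
compound 2 `CCOc1cc(C(=CC#N)c2ccc(N(C)C)cc2)ccc1OC` gives 31 nM

Both numbers come from a functional assay on HCT-116 cells (Homo sapiens) for cytotoxicity, read by scintillation counting and thymidine incorporation, with a stated time of 72 h (on this read-out lower numbers stand for stronger inhibition and higher numbers for weaker inhibition), and compound 1 holds the higher of the two, with compound 2 lower by more than the scatter. Compound 3 `COc1cc(OC)cc(C(=CC#N)c2ccc(OC)c(OC)c2)c1` is not yet measured. The change methoxy in place of acetamido on an aromatic carbon puts methoxy in place of acetamido on an aromatic carbon, ortho to a methoxy group. Among the measured compounds shown here, no measured step covers this change, so neither direction is favoured. The estimated step of a 1.2-fold lower number from compound 1 to compound 3 (0.06 log units; within the scatter) is expected to stay within the scatter. For compound 3 the estimate is 80 nM and the expected range runs from 20 nM to 320 nM on repeat measurement.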

Compound 3, half-maximal inhibitory concentration: 18 nM
Compound 3: the middle estimate sits 4.4-fold (0.65 log units) above what was measured, outside the stated range (below it).
By their numbers in this assay, from the lowest: compounds 3 and 2 (each within the scatter of the next); then compound 1.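

Methoxy in place of acetamido, ortho to a methoxy group, gives a 5.1-fold lower number from compound 1 to compound 3 (0.71 log units; beyond the scatter) in this assay and is the only single-place step measured so far. At this position, then, the acetamido group is not required for a low number, and the smaller group without a hydrogen-bond donor does better. This single step cannot separate the effect of size from that of losing the donor, and no measurement at hand explains it.

As far as these compounds go, whether a hydroxyl or an amine at this position would match methoxy remains open.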